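Cyano for nitro on the shared aryl of compound 1

The source may report more compounds than this note shows. Statements on the series, on what has been measured and on what is new or still open speak of the compounds shown alone.

Compound 1 `CCOC(=O)N1CCCN(/[N+]([O-])=N/Oc2ccc([N+](=O)[O-])cc2[N+](=O)[O-])CC1`: 950 nM
Compound 2 `CCOC(=O)N1CCN(/[N+]([O-])=N/Oc2ccc(C#N)cc2C#N)CC1`: > 20000 nM
Compound 3 `CCOC(=O)N1CCCN(/[N+]([O-])=N/Oc2ccc([N+](=O)[O-])cc2C#N)CC1`: 2620 nM

In a functional assay on NCI-H1703 cells (Homo sapiens) for antiproliferative activity, read by MTT assay, with a stated time of 48 h (a lower number here means a stronger inhibitor, a higher number a weaker inhibitor), compound 1 gives 950 nM, the lowest of the two numbers shown. Compound 3 gives 2620 nM, a step of a 2.8-fold higher number from compound 1 to compound 3 (0.44 log units; beyond the scatter). For compound 2 this assay reports only a limit, > 20000 nM, one of the values at the limit of > 20000 nM in this assay, at which 1 of the 3 values shown sits. Compound 4 `CCOC(=O)N1CCCN(/[N+]([O-])=N/Oc2ccc(C#N)cc2[N+](=O)[O-])CC1` differs from compound 1 by cyano in place of nitro on an aromatic carbon, a cyano in place of nitro on an aromatic carbon, para to a large group. Among the compounds with values here, only the step from compound 1 to compound 3 bears on this change, and it was modest. A step of similar size and direction is therefore expected, a 2.6-fold higher number from compound 1 to compound 4 (0.42 log units; beyond the scatter). Compound 4 is estimated at 2500 nM, in the range 1000 nM to 7000 nM.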

Compound 4, half-maximal inhibitory concentration: 680 nM
Compound 4: the middle estimate sits 3.7-fold (0.57 log units) above what was measured; the whole stated range lies above it.
By their numbers in this assay, from the lowest: compounds 4 and 1 (each within the scatter of the next); then compound 3. At a limit, above all of these: compound 2.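

Cyano in place of nitro on the aromatic carbon para to a large group, meta to a nitro group, gives a 1.4-fold lower number from compound 1 to compound 4 (0.15 log units; within the scatter) in this assay. The same replacement at the other nitro gave a 2.8-fold higher number from compound 1 to compound 3 (0.44 log units; beyond the scatter), so among these compounds the outcome of this change depends on which nitro it replaces. Nothing given here accounts for that difference.

Going by these compounds, how an amine or a carboxylic acid on this carbon would read in this assay remains open. So does the effect of replacing both nitro groups on the core of compound 1.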